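A few compounds are considered here, and "the series" means these few. Any claim that something is new, unique, unknown or untested is made for them only; others in the source may bear on it.

Notes start from compound 2 (`COC1=CC(=O)c2c(COc3ccc([N+](=O)[O-])cc3)c(C)n(C)c2C1=O`). In a functional assay on MIA PaCa-2 cells (Homo sapiens) for cytotoxicity, read by MTT assay, with a stated time of 72 h (a lower number here means a stronger inhibitor, a higher number a weaker inhibitor), compound 2 gives 355 nM, alongside compound 3 (`COC1=CC(=O)c2c(COc3ccc([N+](=O)[O-])cc3F)c(C)n(C)c2C1=O`) at 417 nM, while compound 1 (`COC1=CC(=O)c2c(c(COc3c(F)cc(F)cc3F)c(C)n2C)C1=O`) lies lower at 86 nM. Compound 4 (`COC1=CC(=O)c2c(COc3ccc(F)cc3)c(C)n(C)c2C1=O`) carries fluoro in place of nitro on an aromatic carbon, fluoro in place of nitro on an aromatic carbon. Among the measured compounds shown here, no measured step makes this exchange. The closest evidence is limited: fluoro in place of hydrogen gave a 1.2-fold higher number from compound 2 to compound 3 (0.07 log units; within the scatter), with the nitro retained. Compound 1, at 86 nM, has fluoro groups and no nitro, but its core also differs from that of compound 2. A modest move towards a lower number is therefore expected in this assay, with an estimated 1.8-fold lower number from compound 2 to compound 4 (0.25 log units; within the scatter). The expected value for compound 4 is 200 nM, within an estimated range of 80 nM to 480 nM.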

Compound 4, half-maximal inhibitory concentration: 493 nM
Compound 4: the middle estimate sits 2.5-fold (0.39 log units) below what was measured; measured number outside the range, above it.
By their numbers in this assay, from the lowest: compound 1; then compounds 2, 3 and 4 (each within the scatter of the next).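

In this assay, fluoro in place of nitro on an aromatic carbon, para to a large group, gives a 1.4-fold higher number from compound 2 to compound 4 (0.14 log units; within the scatter) and so no readable shift. At this position the nitro, with its three heavy atoms and two hydrogen-bond acceptors, can give way to a single fluorine atom with no hydrogen-bond acceptor, without a change beyond the scatter.

An amine, a carboxylic acid or a longer chain at this place does not appear among the compounds shown, so how far this tolerance extends stays open. Nothing measured here accounts for the flat result.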